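A few compounds are considered here, and "the series" means these few. Any claim that something is new, unique, unknown or untested is made for them only; others in the source may bear on it.

Compound 1 `COC(=O)c1cc(-c2cccc(NC(=O)c3ccc(/C=C/C(=O)c4ccc(F)cc4)cc3)c2)on1`: > 20 ug/mL in an ADME assay on Vero cells (Chlorocebus sabaeus) for cytotoxicity, read by MTT assay, with a stated time of 72 h; on this read-out lower numbers stand for higher toxicity in this test and higher numbers for lower toxicity in this test
Compound 2 `COC(=O)c1cc(-c2cccc(NC(=O)c3ccc(/C=C/C(=O)c4cccnc4)cc3)c2)on1`: "not determined" (no result reported) in this assay

For compound 1 the value > 20 ug/mL is a limit of this assay, not a number. Going by the values given here, compound 2 has no result at all in this assay, so it stands nowhere on the scale; the only value shown sits at the limit of > 20 ug/mL in this assay, at which 1 of the 2 values shown sits. Compound 3 `COC(=O)c1cc(-c2cccc(NC(=O)c3ccc(/C=C/C(=O)c4cccc([N+](=O)[O-])c4)cc3)c2)on1` differs from compound 2 by 3-nitrophenyl in place of pyridin-3-yl on a carbonyl carbon. Among the compounds with values here, no step between two measured compounds exists, so the size and direction of the change in this assay cannot be read from these data; no shift beyond the scatter is assumed. Compound 3 is expected near 20 ug/mL, between 5 ug/mL and 40 ug/mL, most likely reported again only as a limit.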

Compound 3, half-maximal cytotoxic concentration: > 40 ug/mL
Compound 3: only a limit was reported; the forecaster's own chance of this, stated with the estimate: 70%; middle value at least 2.0-fold (0.30 log units) from the limit.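

Going by these compounds alone, the results for compound 1 and compound 3 in this assay are both limits, and no step between them can be read. The compounds shown leave open whether 3-nitrophenyl in place of 4-fluorophenyl changes toxicity in this test at all.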